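From 4-methylphenyl to phenyl in an inactive series

The source may report more compounds than this note shows. Statements on the series, on what has been measured and on what is new or still open speak of the compounds shown alone.

Compound 1 `COc1cc(-n2ncnc2-c2ccc(C)cc2)cc(OC)c1OC` gives > 10000 nM (a limit)
Compound 2 `COc1cc(-c2ncnn2-c2ccc([N+](=O)[O-])cc2)cc(OC)c1OC` gives > 10000 nM (a limit)
Compound 3 `COc1cc(-c2ncnn2-c2ccc(Cl)cc2)cc(OC)c1OC` gives > 10000 nM (a limit)

In a functional assay on K562 cells (Homo sapiens) for antiproliferative activity, read by MTT assay, with a stated time of 72 h (on this read-out higher numbers stand for weaker inhibition and lower numbers for stronger inhibition), compound 1 gives > 10000 nM as a limit and not as a number. The whole series stands at the limit of > 10000 nM in this assay, at which 3 of the 3 values shown sit, and so offers no exact value to work from.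

Compound 4 `COc1cc(-n2ncnc2-c2ccccc2)cc(OC)c1OC` has not yet been measured. Its difference from compound 1, hydrogen in place of methyl on an aromatic carbon in full, is hydrogen in place of methyl on an aromatic carbon, para to a large group, or 4-methylphenyl to phenyl.

Among the compounds with values here, the only measured step between close relatives is a step that the two limits leave unreadable from compound 2 to compound 3 and it concerns chloro in place of nitro on an aromatic carbon. Within the data shown here, that step has no size to carry over, and no measured step involves the methyl group itself. Nothing in these data points to a gain in inhibition, so compound 4 is expected to stay close to the limit shared by the others. The expected step is a number no higher from compound 1 to compound 4 (the limit leaves the size open) and no direction can be expected from these data. For compound 4 the estimate is 10000 nM with an expected range from 3000 nM to 30000 nM and a good chance that the outcome is again only a limit.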

Compound 4, half-maximal inhibitory concentration: > 10000 nM
Compound 4 ended at the assay's limit; the forecaster's own chance of this, stated with the estimate: 85%; the middle value sits exactly at the limit.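

Compound 1 and compound 4 are both reported only as limits and not as numbers in this assay, so the step between them cannot be read: the limit of > 10000 nM in this assay, at which 4 of the 4 values shown sit.

The compounds shown leave open how strongly any of them inhibits K562 cell growth, and whether any change to the shared core would give an exact value.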